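Swapping methyl for benzyl at the amine nitrogen

A few compounds are considered here, and "the series" means these few. Any claim that something is new, unique, unknown or untested is made for them only; others in the source may bear on it.

Of the compounds shown here, three sharing one core have been tested in a functional assay on trachea (Cavia porcellus); a lower number here means a stronger inhibitor, a higher number a weaker inhibitor. Compound 1 `CO[C@@]12CCN(C)C[C@H]1[C@H](c1ccc(Br)cc1)C(C#N)=C(N)O2` gives 7900 nM. Compound 2 `CO[C@@]12CCN(C)C[C@H]1[C@H](c1ccc(Cl)cc1)C(C#N)=C(N)O2` gives 10500 nM, and compound 3 `CO[C@@]12CCN(C)C[C@H]1[C@H](c1ccc(Cl)cc1Cl)C(C#N)=C(N)O2` gives 14900 nM. The gaps between them are small: a 1.3-fold higher number from compound 1 to compound 2 (0.12 log units; within the scatter), a 1.9-fold higher number from compound 1 to compound 3 (0.28 log units; within the scatter) and a 1.4-fold higher number from compound 2 to compound 3 (0.15 log units; within the scatter) all lie within the scatter of repeated measurements, so compound 3 cannot be separated from compounds 1 and 2 on these numbers; the three sit together.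

Compound 4 `CO[C@@]12CCN(Cc3ccccc3)C[C@H]1[C@H](c1ccc(Cl)cc1Cl)C(C#N)=C(N)O2` is compound 3 with a single change: phenyl in place of hydrogen on a saturated chain carbon bound to an amine nitrogen in a ring; cut one bond further out, this reads as methyl to benzyl. None of the three measured steps touches the amine nitrogen in the ring or the group attached through it; every one of them alters a halogen on an aromatic carbon of the ring that sits on the saturated ring carbon. Going by the values given here, the data thus hold no step from which the size or direction of this change in this assay can be read. Because compound 3 gives 14900 nM and nothing shown argues for a move away from it, compound 4 is expected to land near that number. The expected step is a 1.0-fold higher number from compound 3 to compound 4 (0.00 log units; within the scatter), carrying a wide range. The estimate for compound 4 in this assay is 15000 nM, between 3000 nM and 70000 nM.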

Compound 4, half-maximal inhibitory concentration: 18300 nM
Estimate against measurement, compound 4: 1.2-fold (0.09 log units) below; the measured number falls inside the stated range.
By their numbers in this assay, from the lowest: compounds 1, 2, 3 and 4 (each within the scatter of the next, the first and the last beyond it).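

In this assay the step at the amine nitrogen in the ring, a 1.2-fold higher number from compound 3 to compound 4 (0.09 log units; within the scatter), lies within the scatter, so methyl and benzyl cannot be told apart at this position on these numbers. Going by these compounds alone, the earlier compounds differed only in halogens on the aromatic ring, whereas this pair gives the first reading at the nitrogen: adding a phenyl to the methyl carbon, with its 6 heavy atoms, leaves a number that cannot be separated from that of compound 3. No measured evidence here bears on this result.

This single pair, both members carrying 2,4-dichlorophenyl, leaves open whether the same change would read the same way with the 4-bromophenyl of compound 1 or the 4-chlorophenyl of compound 2. It also leaves open how the number would respond to other groups on that nitrogen, such as a bare hydrogen, a longer chain like phenylethyl, or a chain ending in a carboxylic acid or a second amine.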